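The source may hold more compounds than are shown below. What is called first, only, known or untested is meant among the compounds shown, and "the series" means these compounds.

Of the compounds shown here, three with a shared core have been measured in a functional assay on HeLa cells (Homo sapiens) for antiproliferative activity, read by MTT assay, with a stated time of 72 h; a higher number here means a weaker inhibitor, a lower number a stronger inhibitor. Compound 1 `O=C1O[C@H]([C@@H](O)Cn2cc(-c3ccc(Br)cc3)nn2)C(OCc2ccccc2)=C1OCc1ccccc1` gives 3910 nM. Compound 2 `Cc1ccc(-c2cn(C/C=C3\OC(=O)C(OCc4ccccc4)=C3OCc3ccccc3)nn2)cc1`, which differs from the other two in several places, gives 7480 nM. Compound 3 `O=C1O[C@H]([C@@H](O)Cn2cc(-c3cccc(O)c3)nn2)C(OCc2ccccc2)=C1OCc1ccccc1` gives 39300 nM, the highest of the three numbers; compound 2 is nearest to it and compound 1 furthest. Going by the values given here, the only single-place step among them is a 10-fold higher number from compound 1 to compound 3 (1.00 log units; beyond the scatter), and it makes compound 3 the weakest inhibitor of the set.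

Compound 4 `CCCCc1cn(C[C@H](O)[C@H]2OC(=O)C(OCc3ccccc3)=C2OCc2ccccc2)nn1` arises from compound 3 by the change (butyl in place of 3-hydroxyphenyl on an aromatic carbon). Among the compounds with values here, no measured pair shows an aryl group replaced by a chain, so the step from compound 1 to compound 3 is the only guide: leaving the 3-hydroxyphenyl group removes what made the number rise there, and the number is expected to fall back partway, though with wide uncertainty. Compound 4 is therefore estimated at 12000 nM in this assay, between 3000 nM and 50000 nM, meaning an expected step of a 3.3-fold lower number from compound 3 to compound 4 (0.52 log units; beyond the scatter).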

Compound 4, half-maximal inhibitory concentration: 18100 nM
Compound 4: middle estimate off by 1.5-fold (0.18 log units), on the low side, and the stated range covers the measured number.
By their numbers in this assay, from the lowest: compounds 1 and 2 (each within the scatter of the next); then compound 4; then compound 3.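

In this assay, an aromatic ring on this carbon of the five-membered ring is not needed for a number lower than that of the 3-hydroxyphenyl group: butyl in its place gives a 2.2-fold lower number from compound 3 to compound 4 (0.34 log units; beyond the scatter), although butyl has no ring and no hydrogen-bond donor or acceptor. Butyl does not match 4-bromophenyl, however, as its exchange for that group gives a 4.6-fold higher number from compound 1 to compound 4 (0.67 log units; beyond the scatter), so among these three groups butyl falls in the middle and the two aryl groups lie on either side of it. Nothing given here accounts for this order.

Still open, on these data alone, is how a plain phenyl group, a longer chain or a chain ending in an amine would stand at this carbon. A plain phenyl group would help to separate the part played by the bromine from that of the hydroxyl group.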